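Cyclohexyl to Cyclopropyl on a Protected Sugar Core

A few compounds are considered here, and "the series" means these few. Any claim that something is new, unique, unknown or untested is made for them only; others in the source may bear on it.

Compound 1 `O[C@@H]1[C@@H](OCc2ccccc2)[C@H](OCc2ccccc2)[C@@H](COCc2ccccc2)O[C@]12CCCO2`: "not active" (no number reported)
Compound 2 `O[C@@H]1[C@@H](OCc2ccccc2)[C@H](OCc2ccccc2)[C@@H](COCc2ccccc2)O[C@H]1CC1CCCCC1`: 4100 nM
Compound 3 `CCCCOC[C@H]1O[C@@H](CCC)[C@H](O)[C@@H](OCCCC)[C@@H]1OCCCC`: "not active" (no number reported)

Of the compounds shown here, three have been tested in a functional assay on HL-60 cells (Homo sapiens) for antiproliferative activity, read by MTT assay; on this read-out higher numbers stand for weaker inhibition and lower numbers for stronger inhibition. Compound 1 gives "not active" (no number reported) in this assay, with no number reported. Compound 3 likewise gives "not active" (no number reported) and no number. Among the compounds with values here, compound 2 is the only one with a number, 4100 nM, and so it stands as the sole quantified point of reference; the data do not say by how much it differs from compounds 1 and 3.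

Compound 4 `O[C@@H]1[C@@H](OCc2ccccc2)[C@H](OCc2ccccc2)[C@@H](COCc2ccccc2)O[C@H]1CC1CC1` has not yet been measured. It differs from compound 2 in one place: cyclopropyl in place of cyclohexyl on a saturated chain carbon bound to a saturated ring carbon. Within the data shown here, no pair of measured compounds differing in one place exists, so the size of this step cannot be read from a precedent. What the measured set does show is that the shared core, as in compounds 1 and 3, can readily lose all measurable activity, while compound 2 itself is only a weak inhibitor. The step of a 2.2-fold higher number from compound 2 to compound 4 (0.34 log units; beyond the scatter) is therefore expected to go toward weaker inhibition, modestly beyond the scatter, with a real chance that no number is returned. Compound 4 is estimated at 9000 nM, with a range from 3000 nM to 30000 nM.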

Compound 4, half-maximal inhibitory concentration: "not active" (no number reported)
Compound 4: no number reported; there is nothing to compare the estimate with.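

In this assay compound 4 gives "not active" (no number reported), so no step can be read from compound 2, at 4100 nM, to compound 4. Nothing measured here bears on this result. The compounds shown leave open how large the change from cyclohexyl to cyclopropyl is on this read-out, since only compound 2 carries a number.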